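Methoxycarbonyl in Place of Hydroxymethyl: Expected Cytotoxicity

The compounds below may be only part of what the source reports. "The series", "measured", "known", "first", "only" and "open" are said of these compounds alone.

Of the compounds shown here, two have so far been tested in a functional assay on HepG2 cells (Homo sapiens) for cytotoxicity, read by MTT assay; on this read-out lower numbers stand for stronger inhibition and higher numbers for weaker inhibition. Compound 1 `C=C1C(=O)O[C@H]2C/C(C)=C/[C@@H](O)C/C(C)=C/CC/C(C)=C/C[C@H]12` reaches only the limit of the assay, giving > 5 ug/mL. Compound 2 `C=C1C(=O)O[C@H]2/C=C(\C)CC/C=C(\CO)CC/C=C(\C)CC[C@@H]12` likewise sits at that limit, with > 5 ug/mL. Both values shown are limits and not numbers, as the limit of > 5 ug/mL in this assay, at which 2 of the 2 values shown sit, states, so compound 2 cannot be ranked against compound 1 in either direction. The new compound 3 `C=C1C(=O)O[C@H]2/C=C(\C)CC/C=C(\C(=O)OC)CC/C=C(\C)CC[C@@H]12` differs from compound 2 in a single place: methoxycarbonyl in place of hydroxymethyl on a double-bonded ring carbon. Going by the values given here, with only a limit known for compound 2, no measured step anchors this change, and nothing here ties either group to a stronger or weaker effect. The expected step is small, a step that the limit leaves unreadable from compound 2 to compound 3, with no direction favoured beyond the scatter. Compound 3 is estimated at 8 ug/mL, in a range from 3 ug/mL to 25 ug/mL, and is most likely to be reported again only as a limit.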

Compound 3, half-maximal inhibitory concentration: > 5 ug/mL
Compound 3 ended at the assay's limit; the forecaster's own chance of this, stated with the estimate: 65%; the middle value does not contradict the limit.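

In this assay, no step can be read between compound 2 and compound 3, because both results are only limits and not numbers: the limit of > 5 ug/mL in this assay, at which 3 of the 3 values shown sit.

The compounds shown leave open whether methoxycarbonyl or hydroxymethyl on the double-bonded ring carbon gives stronger inhibition, and how strongly compound 1, compound 2 or compound 3 actually inhibits.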